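A few compounds are considered here, and "the series" means these few. Any claim that something is new, unique, unknown or untested is made for them only; others in the source may bear on it.

Measured so far:
- compound 1, `CSc1cnc2ccccc2c1[Se]CC#CCO`: 3.4 ug/mL
- compound 2, `CCOC(=O)OCC#CCSc1c(SC)cnc2ccccc12`: 33.1 ug/mL

Both numbers come from a functional assay on SW707 cells (Homo sapiens) for antiproliferative activity, with a stated time of 72 h; a higher number here means a weaker inhibitor, a lower number a stronger inhibitor. Of the two compounds, compound 2 has the higher number, so it is the weaker inhibitor; compound 1 gives 3.4 ug/mL, a gap far beyond the usual scatter of this measurement.

The next compound is compound 3, `CSc1cnc2ccccc2c1SCC#CCO`, which is not yet measured in this assay. It differs from compound 2 in one place: hydrogen in place of ethoxycarbonyl on an oxygen on a saturated carbon. The shared core and the sulfur-linked chain are kept.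

Among the compounds with values here, no measured pair shows this exact change, so its effect is open. Because compound 1 gives 3.4 ug/mL while compound 2 gives 33.1 ug/mL, the free hydroxy end appears compatible with a lower number, and compound 3 is expected to move toward the stronger side, with a step of a 4.1-fold lower number from compound 2 to compound 3 (0.62 log units; beyond the scatter). The estimate for compound 3 in this assay is 8 ug/mL, with a range from 2.5 ug/mL to 25 ug/mL.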

Compound 3, concentration for 50% inhibition: 34.9 ug/mL
Estimate against measurement, compound 3: 4.4-fold (0.64 log units) below, and the stated range ends below it.
By their numbers in this assay, from the lowest: compound 1; then compounds 2 and 3 (each within the scatter of the next).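

In this assay, replacing the ethoxycarbonyl on the oxygen with hydrogen gives a 1.1-fold higher number from compound 2 to compound 3 (0.02 log units; within the scatter), so on this oxygen the two cannot be told apart. The free hydroxy end alone therefore does not bring a lower number. Compound 1 and compound 3 both carry that hydroxy end, and their chains on the aromatic carbon differ only in selenium against sulfur, which gives a 10-fold higher number from compound 1 to compound 3 (1.01 log units; beyond the scatter), so in this pair the large difference goes with that single atom.

On these data alone, whether selenium has the same effect when the oxygen carries ethoxycarbonyl remains open, as does whether an acetyl or methyl group on that oxygen, or an amine in its place, would behave like these two. Nothing measured here explains why the selenium and sulfur compounds differ.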